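Difluorophenyl on the alkyne of a weak adenosine ligand

This account rests on a few compounds, and the source may have more. Where it says the series, first, only, none or still open, it means among the compounds named here.

The series is followed in an assay on isolated protein for binding affinity to adenosine receptor A3 (Homo sapiens); on this read-out lower numbers stand for stronger inhibition and higher numbers for weaker inhibition. Compound 3, `CNC(=O)[C@]12C[C@@H]1[C@@H](n1cnc3c(NCc4cccc(Cl)c4)nc(C#Cc4ccccc4)nc31)[C@H](O)[C@@H]2O`, shows only a limit in this assay, at >= 99 nM; this is a limit of the assay and not a number. The same holds across the set, as compound 1, `CCOC(=O)[C@]12C[C@@H]1[C@@H](n1ccc3c(NCCCc4ccc(OC)c(O)c4)nc(C#Cc4ccccc4)nc31)[C@H](O)[C@@H]2O`, gives >= 99 nM in this assay. Compound 2, `[N-]=[N+]=Nc1ccc(CNc2nc(C#Cc3ccc(F)c(F)c3)nc3c2ncn3[C@H]2[C@H](O)[C@H](O)[C@]3(CO)C[C@H]23)cc1`, likewise gives >= 99 nM in this assay, and it carries the 2-(3,4-difluorophenyl)ethynyl group. Compound 4, `CNC(=O)[C@]12C[C@@H]1[C@@H](n1cnc3c(NCc4cccc(Cl)c4)nc(C#Cc4ccc(F)c(F)c4)nc31)[C@H](O)[C@@H]2O`, has not been measured; it differs from compound 3 by 3,4-difluorophenyl in place of phenyl on a triple-bonded carbon. Among the measured compounds shown here, no step between measured compounds is available, so the size of the change can only be guessed. Because every value sits at the limit of >= 99 nM in this assay, at which 3 of the 3 values shown sit, nothing here points to a gain beyond the scatter, and a result at the limit again is the likeliest outcome. Compound 4 is therefore expected to stay weak in this assay, with an estimated step that the limit leaves unreadable from compound 3 to compound 4. Compound 4 is estimated at 300 nM, within a range from 99 nM to 3000 nM.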

Compound 4, inhibition constant: >= 99 nM
Compound 4 ended at the assay's limit; the forecaster's own chance of this, stated with the estimate: 70%; the middle value does not contradict the limit.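

On these data alone, compound 3 and compound 4 both sit at the limit of this assay, so no step can be read between them, and the effect of 3,4-difluorophenyl in place of phenyl remains unknown. The compounds shown leave open which change, if any, would move a value off this limit: the limit of >= 99 nM in this assay, at which 4 of the 4 values shown sit.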